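Swapping cyclohexyl for benzylamino on a shared core

A few compounds are considered here, and "the series" means these few. Any claim that something is new, unique, unknown or untested is made for them only; others in the source may bear on it.

Measured compounds:
- compound 1, `Cn1ncc([N+](=O)[O-])c1C(=O)Nc1ccc2nc(NC(=O)C3CCCCC3)sc2c1`, gives 0.026 ug/mL in a functional assay on WI-38 VA13 cells (Homo sapiens) for cytotoxicity; on this read-out higher numbers stand for an effect only at larger amounts of compound and lower numbers for an effect already at smaller amounts
- compound 2, `O=C(Nc1ccc2nc(NC(=O)C3CCCCC3)sc2c1)c1c(Cl)cccc1Cl`, gives 0.015 ug/mL in this assay
- compound 3, `C=CCOC(=O)Nc1ccc2nc(NC(=O)C3CCCCC3)sc2c1`, gives 0.58 ug/mL in this assay

All three share one core and differ in a single group. Compound 2 has the lowest number of the three, but the gap a 1.7-fold lower number from compound 1 to compound 2 (0.24 log units; within the scatter) lies within the scatter, so compounds 1 and 2 cannot be told apart. Compound 3 stands clearly apart: a 22-fold higher number from compound 1 to compound 3 (1.35 log units; beyond the scatter) and a 39-fold higher number from compound 2 to compound 3 (1.59 log units; beyond the scatter) are both large.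

Compound 4, `O=C(NCc1ccccc1)Nc1nc2ccc(NC(=O)c3c(Cl)cccc3Cl)cc2s1`, differs from compound 2 by benzylamino in place of cyclohexyl on a carbonyl carbon. Going by the values given here, none of the measured steps bears on this change: all three vary a different group, and the cyclohexyl end stays the same in every measured compound. With no guide, the expected step of a 2.0-fold higher number from compound 2 to compound 4 (0.30 log units; within the scatter) is set near no change but with wide uncertainty. Compound 4 is therefore estimated at 0.03 ug/mL in this assay, in a range from 0.005 ug/mL to 0.2 ug/mL.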

Compound 4, half-maximal effective concentration: 0.15 ug/mL
Estimate against measurement, compound 4: 5.0-fold (0.70 log units) below, within the range that was stated.
By their numbers in this assay, from the lowest: compounds 2 and 1 (each within the scatter of the next); then compound 4; then compound 3.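

Going by these compounds alone, until this result, the cyclohexyl end had stayed the same in every compound, so nothing showed whether changing it would matter. In this assay, benzylamino in place of cyclohexyl on a carbonyl carbon gives a 10-fold higher number from compound 2 to compound 4 (1.00 log units; beyond the scatter), so this position does respond to change, with a shift beyond the usual scatter. The swap replaces a non-aromatic carbon ring with an aromatic one and adds a nitrogen bearing a hydrogen-bond donor, and no supporting measurement explains the shift.

This single step cannot separate the ring change from the added nitrogen, a separation that a benzyl or cyclohexylamino group on the same carbonyl carbon could offer. On these data alone, it also remains open whether the step would be similar with allyloxy or 1-methyl-4-nitro-1H-pyrazol-5-yl in place of 2,6-dichlorophenyl.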